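Dropping the trifluoromethyl group from compound 2

The source may report more compounds than this note shows. Statements on the series, on what has been measured and on what is new or still open speak of the compounds shown alone.

In a functional assay on DU-145 cells (Homo sapiens) for antiproliferative activity, read by MTT assay, with a stated time of 72 h (on this read-out lower numbers stand for stronger inhibition and higher numbers for weaker inhibition), compound 2 (`FC(F)(F)c1ccc(COc2ccc(Nc3ncnc4cc5c(cc34)OCCOCCOCCOCCO5)cc2)cc1`) gives 8800 nM and stands within the scatter of compound 1 (`c1ccc(COc2ccccc2Nc2ncnc3cc4c(cc23)OCCOCCOCCO4)cc1`), which gives 13900 nM in the same measurements. Compound 3 (`O=[N+]([O-])c1ccc(COc2ccccc2Nc2ncnc3cc4c(cc23)OCCOCCO4)cc1`) gives 85600 nM and lies well beyond the scatter from compound 2, whose number is the lower of the two.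

Compound 4 (`c1ccc(COc2ccc(Nc3ncnc4cc5c(cc34)OCCOCCOCCOCCO5)cc2)cc1`) keeps everything in compound 2 except one feature: hydrogen in place of trifluoromethyl on an aromatic carbon, turning 4-(trifluoromethyl)benzyl to benzyl (hydrogen in place of trifluoromethyl on an aromatic carbon). Among the compounds with values here, no measured pair shows this change on its own. Unlike compound 2, compound 1 carries a plain benzyloxy group, though it also differs elsewhere, and with 13900 nM it stays within the scatter of compound 2. A small rise in the number is therefore expected, or no change beyond the scatter. The estimated step is a 1.4-fold higher number from compound 2 to compound 4 (0.13 log units; within the scatter) and is expected to remain within the scatter. In this assay compound 4 is estimated at 12000 nM (range 4500 nM to 32000 nM).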

Compound 4, half-maximal inhibitory concentration: 8800 nM
Compound 4: the middle estimate sits 1.4-fold (0.13 log units) above what was measured; the measured number falls inside the stated range.
By their numbers in this assay, from the lowest: compounds 2, 4 and 1 (each within the scatter of the next); then compound 3.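

In this assay, within the data shown here, hydrogen in place of trifluoromethyl on an aromatic carbon gives no change at the digits printed from compound 2 to compound 4 (within the scatter) and so shows this change on its own for the first time, which the earlier compounds, differing in several places at once, could not do. At this position, with the rest of compound 2 held fixed, the trifluoromethyl group can therefore be left out with no change beyond the scatter on this read-out. Nothing measured here offers an explanation for this result.

As far as these compounds go, whether a methoxy group, an amine or a carboxylic acid at the same position would also leave the number in place stays open. Also open, from the compounds shown here alone, is whether the same swap would give the same result on the core of compound 1 or that of compound 3.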